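A few compounds are considered here, and "the series" means these few. Any claim that something is new, unique, unknown or untested is made for them only; others in the source may bear on it.

Measured in a functional assay on HEK293 cells for agonist activity at D(4) dopamine receptor (Homo sapiens), read by FLIPR; a lower number here means a smaller maximal response, a higher number a larger maximal response:
compound 1 `Cc1ccc(C(=O)NCN2CCC(c3cccc[n+]3[O-])CC2)cc1C` gives 65%
compound 2 `Cc1ccc(Cl)c(NC(=O)CN2CCC(c3cccc[n+]3[O-])CC2)c1Cl` gives 62%

Compound 1 carries the larger of the two figures, yet the gap to compound 2 lies within the scatter, so the two cannot be told apart. Compound 3 `O=C(NCN1CCC(c2cccc[n+]2[O-])CC1)c1cnccc1Cl` differs from compound 1 in one place: 4-chloropyridin-3-yl in place of 3,4-dimethylphenyl on a carbonyl carbon. Among the compounds with values here, no measured pair here shares this change, so its size is not known from the data. For compound 3 the expected step is a number 9 percentage points lower from compound 1 to compound 3 (within the scatter), a modest drop that may not exceed the scatter. Compound 3 is therefore estimated at 56%, between 38% and 74%.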

Compound 3, largest response reached (reported as efficacy), in percent of the reference or control that the assay uses: 44%
Compound 3: middle estimate off by 12 percentage points, on the high side; the measured number falls inside the stated range.
By their numbers in this assay, from the lowest: compound 3; then compounds 2 and 1 (each within the scatter of the next).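

In this assay the group on the carbonyl carbon turns out to matter: 4-chloropyridin-3-yl in place of 3,4-dimethylphenyl gives a number 21 percentage points lower from compound 1 to compound 3 (beyond the scatter) and so opens the first gap here that clears the scatter. The earlier pair could not show this, as those two compounds differ in more than one place. Nothing available explains the drop. The compounds shown leave open whether the step follows the ring nitrogen or the chlorine. A plain pyridin-3-yl or a 4-chlorophenyl group on that carbonyl carbon would separate the two.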